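From 4-chlorophenyl to 3-chlorophenyl: notes on compound 4

A few compounds are considered here, and "the series" means these few. Any claim that something is new, unique, unknown or untested is made for them only; others in the source may bear on it.

In a functional assay (aorta) for inhibition, with Rattus norvegicus as the target (on this read-out lower numbers stand for stronger inhibition and higher numbers for weaker inhibition), compound 1 (`COC(OC)[C@]1(C)Oc2ccc([N+](=O)[O-])cc2[C@@H](/N=C(\NC#N)Nc2ccc(Cl)cc2)[C@@H]1O`) gives 17500 nM. Compound 2 (`COc1ccc(CN/C(=N/c2c([N+](=O)[O-])ccc3c2CC(O)C(C)(C(OC)OC)O3)NC#N)cc1`) gives 16100 nM, which lies within the usual scatter of the value for compound 1. Compound 3 (`COC(OC)[C@@]1(C)Oc2ccc([N+](=O)[O-])cc2[C@@H](N/C(=N/C#N)NCc2ccccc2)[C@H]1O`) has two separate entries rather than a single number, 7300 nM; 9800 nM (2 entries).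

The next compound to be measured is compound 4 (`COC(OC)[C@]1(C)Oc2ccc([N+](=O)[O-])cc2[C@@H](/N=C(\NC#N)Nc2cccc(Cl)c2)[C@@H]1O`). It has 3-chlorophenyl in place of 4-chlorophenyl on an amine nitrogen, with the rest of the structure unchanged: 3-chlorophenyl in place of 4-chlorophenyl on an amine nitrogen.

For the measured compounds named here, no measured pair differs in one place only, so this change has no direct precedent. In this assay, no step beyond the scatter is expected, in either direction. The expectation is therefore anchored on compound 1 at 17500 nM. The expected size of the change is a 1.2-fold lower number from compound 1 to compound 4 (0.07 log units; within the scatter). Compound 4 is estimated at 15000 nM, with an expected range of 7000 nM to 32000 nM.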

Compound 4, half-maximal inhibitory concentration: 30500 nM
Estimate against measurement, compound 4: 2.0-fold (0.31 log units) below; the measured number falls inside the stated range.
By their numbers in this assay, from the lowest: compounds 2, 1 and 4 (each within the scatter of the next).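

For the compounds shown here, this is the first step that changes one place only, and it gives a direct reading on the aryl group on the amine nitrogen: in this assay, 3-chlorophenyl in place of 4-chlorophenyl gives a 1.7-fold higher number from compound 1 to compound 4 (0.24 log units; within the scatter). That step stays within the scatter: the read-out does not separate the two chlorophenyl groups, and no preference between them can be stated at this place. Repeat entries in the series show how far the numbers of one compound can spread on this read-out: the several entries of compound 3 in this assay, 7300 nM; 9800 nM (2 entries)

The compounds shown leave open whether this place responds at all to a change larger than moving the chlorine; a single pair is all that is known of it. A 3-methoxyphenyl or a pyridine ring on the same nitrogen, set on the core of compound 1, would test that.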